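The source may report more compounds than this note shows. Statements on the series, on what has been measured and on what is new or still open speak of the compounds shown alone.

In a functional assay on PC-12 cells (Rattus norvegicus) for inhibition, read by sulforhodamine B assay (on this read-out lower numbers stand for stronger inhibition and higher numbers for weaker inhibition), compound 1 `O=C1NC(=O)C(Cc2ccc(OCC3CCCCC3)cc2)S1` gives 26000 nM and compound 2 `O=C1N=C(O)S/C1=C\c1ccc(OCC2CCCCC2)cc1` gives 14000 nM, two values within the scatter of each other. Compound 3 `O=C1NC(=O)C(Cc2ccc(OCC3CCC3)cc2)S1` is not yet measured. It differs from compound 1 in one place: cyclobutyl in place of cyclohexyl on a saturated chain carbon bound to an oxygen on an aromatic ring. Within the data shown here, no measured pair shows this change, so the expectation rests on the structural change alone. A modest move toward weaker inhibition in this assay is expected. The expected step is a 1.5-fold higher number from compound 1 to compound 3 (0.16 log units; within the scatter). Compound 3 is estimated at 38000 nM, with an expected range of 15000 nM to 90000 nM.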

Compound 3, half-maximal inhibitory concentration: > 100000 nM
Compound 3 was reported as a limit (the forecaster's own chance of this, stated with the estimate: 15%); middle value at least 2.6-fold (0.42 log units) from the limit.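

Compound 3 stands in this assay only as a limit (> 100000 nM) and not as a number. On a saturated chain carbon bound to an oxygen on an aromatic ring, cyclobutyl in place of cyclohexyl gives an at least 3.8-fold higher number from compound 1 to compound 3 (0.58 log units; beyond the scatter) and so shows that this place is not indifferent to the group it carries, which compound 1 and compound 2 could not show with cyclohexyl in both. The full size of the step stays unread: the limit of > 100000 nM in this assay, at which 1 of the 3 values shown sits.

On these data alone, whether cycloheptyl, phenyl or an open hexyl chain would hold the level of compound 1 stays open. So does whether cyclobutyl has the same effect on the core of compound 2.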